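Nitro Gives Way to Amino in Compound 4

A few compounds are considered here, and "the series" means these few. Any claim that something is new, unique, unknown or untested is made for them only; others in the source may bear on it.

Of the compounds shown here, three have been tested so far in an ADME assay on Vero cells (Chlorocebus sabaeus) for cytotoxicity; a higher number here means that more compound is tolerated, a lower number that less compound is tolerated. Compound 1 `COc1ccc(-c2nc3cc(C(F)(F)F)ccc3[nH]2)c(OC)c1` reaches only a limit, > 100000 nM. Compound 2 `Fc1cccc(F)c1-c1nc2cc(C(F)(F)F)ccc2[nH]1` gives a real number, 25000 nM. Compound 3 `O=[N+]([O-])c1ccc(-c2nc3cc(Cl)c(Cl)cc3[nH]2)cc1`, the starting point of this account, also stands at a limit, >= 100000 nM. Its position in this assay is therefore known only as a limit, not as a number.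

Compound 4 `Nc1ccc(-c2nc3cc(Cl)c(Cl)cc3[nH]2)cc1` differs from it in one place: amino in place of nitro on an aromatic carbon. This puts amino in place of nitro on an aromatic carbon, para to a large group. Going by the values given here, no measured pair in the set shows this change on its own, so any expectation here is loose. Compound 2, at 25000 nM, shows that a real number can be reached within this small set, so a moderate fall in tolerated concentration is the expected direction. The expected size is an estimated step of an at least 2.0-fold lower number from compound 3 to compound 4 (0.30 log units; that floor lies within the scatter), although no change beyond the scatter also remains possible. For compound 4 the estimate is 50000 nM, with an expected range from 15000 nM to 100000 nM.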

Compound 4, half-maximal cytotoxic concentration: >= 100000 nM
Compound 4 ended at the assay's limit (the forecaster's own chance of this, stated with the estimate: 40%); at least 2.0-fold (0.30 log units) between middle value and limit.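

No step can be read from compound 3 to compound 4 in this assay because both compounds stand at the same limit: the limit of >= 100000 nM in this assay, at which 2 of the 4 values shown sit.

The compounds shown leave open whether amino in place of nitro changes the tolerated concentration at all, and in which direction.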